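The source may report more compounds than this note shows. Statements on the series, on what has been measured and on what is new or still open speak of the compounds shown alone.

Measured in a functional assay on CWR22R cells (Homo sapiens) for antiproliferative activity, read by CCK-8 assay, with a stated time of 6 days; a lower number here means a stronger inhibitor, a higher number a weaker inhibitor:

- compound 1 `CC(O)c1cccc(C(=O)N[C@@H](C)Cn2ccc(-c3ccc(C#N)c(Cl)c3)n2)c1`: 20100 nM
- compound 2 `CC(=O)c1ccc(C(=O)N[C@@H](C)Cn2ccc(-c3ccc(C#N)c(Cl)c3)n2)cc1`: "not determined" (no result reported)
- compound 3 `C[C@@H](Cn1ccc(-c2ccc(C#N)c(Cl)c2)n1)Nc1cccnc1`: 21600 nM

Compound 3, at 21600 nM, lies within the scatter of compound 1, at 20100 nM, and compound 2 offers no number for comparison. The next compound to be tested is compound 4 `C[C@@H](Cn1ccc(-c2ccc(C#N)c(Cl)c2)n1)Nc1nccc(Cl)n1`. It carries 4-chloropyrimidin-2-yl in place of pyridin-3-yl on an amine nitrogen.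

Among the compounds with values here, no measured pair in this small set differs in one place only, so the data do not show what such an exchange does in this assay. The expectation rests on compound 3 at 21600 nM and on compound 1 at 20100 nM, and it is therefore uncertain. A step beyond the scatter is not expected, though any drift is more likely towards a lower number. The expected step is a 1.4-fold lower number from compound 3 to compound 4 (0.16 log units; within the scatter). For compound 4 the estimated value is 15000 nM, with an expected range from 5000 nM to 40000 nM.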

Compound 4, half-maximal inhibitory concentration: > 30000 nM
Compound 4: a limit, no number; the forecaster's own chance of this, stated with the estimate: 20%; at least 2.0-fold (0.30 log units) between middle value and limit.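

In this assay, the exchange on the amine nitrogen gives an at least 1.3-fold higher number from compound 3 to compound 4 (0.14 log units; that floor lies within the scatter), the only step at one place among the compounds shown. Compound 4 has a limit of the assay, > 30000 nM, and not a number, so the full size of the step cannot be read: the limit of > 30000 nM in this assay, at which 1 of the 4 values shown sits. Even so, the result shows that 4-chloropyrimidin-2-yl does not give the lower number that would mark a gain over pyridin-3-yl at this position.

From the compounds shown here alone, what remains open is how far compound 4 lies beyond the limit, and whether the chlorine or the added ring nitrogen accounts for the result. A plain pyrimidin-2-yl on the same amine nitrogen would separate these two changes, and a methoxy group in place of the chlorine would test that position further.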